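Azepane urea in place of methylpyrrolidine urea

This account rests on a few compounds, and the source may have more. Where it says the series, first, only, none or still open, it means among the compounds named here.

Compound 3 `CC1CCN(C(=O)N2CC(c3nc(-c4cccc(Cl)c4)no3)C2)C1` stands at the bottom of what is shown. In an assay on HEK293 cells for positive allosteric modulation of metabotropic glutamate receptor 5 (Homo sapiens), read by FLIPR (on this read-out lower numbers stand for an effect already at smaller amounts and higher numbers for an effect only at larger amounts of compound), compound 3 gives only a limit, > 10000 nM. Compound 2 `O=C(C1CCCO1)N1CC(c2nc(-c3cccc(Cl)c3)no2)C1` likewise returns a limit in this assay, > 10000 nM. Both rest on (the limit of > 10000 nM in this assay, at which 2 of the 3 values shown sit). Within the data shown here, compound 1 `CC1CCCC(C(=O)N2CC(c3nc(-c4cccc(Cl)c4)no3)C2)C1` is the single numbered value of the set, 410 nM in this assay.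

Compound 4 `O=C(N1CCCCCC1)N1CC(c2nc(-c3cccc(Cl)c3)no2)C1` carries azepan-1-yl in place of 3-methylpyrrolidin-1-yl on a carbonyl carbon. The measured steps that touch the group on the carbonyl carbon are an at least 24-fold higher number from compound 1 to compound 2 (1.38 log units; beyond the scatter) and an at least 24-fold higher number from compound 1 to compound 3 (1.38 log units; beyond the scatter); the remaining pair gives a step that the two limits leave unreadable from compound 2 to compound 3. Among the measured compounds shown here, none of these exchanges one ring-nitrogen amine for another, so no measured step bears directly on the move from compound 3 to compound 4, and within the ureas the only reading available is the limit of compound 3. The expectation for compound 4 in this assay is therefore a value at or near that limit, with the step of an at least 1.1-fold lower number from compound 3 to compound 4 (0.04 log units; that floor lies within the scatter) expected to stay within the scatter. Compound 4 is estimated at 9000 nM, with a range from 1500 nM to 30000 nM.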

Compound 4, half-maximal effective concentration: 47 nM
Beside the measured number, compound 4's estimate is 190-fold (2.28 log units) above it; measured number below the stated range.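

Notes on the group on the carbonyl carbon: in this assay the urea linkage is not in itself disqualifying, as azepan-1-yl in place of 3-methylpyrrolidin-1-yl gives an at least 210-fold lower number from compound 3 to compound 4 (2.32 log units; beyond the scatter), and azepan-1-yl in place of oxolan-2-yl gives an at least 210-fold lower number from compound 2 to compound 4 (2.32 log units; beyond the scatter). Azepan-1-yl also improves on the 3-methylcyclohexyl amide, with an 8.7-fold lower number from compound 1 to compound 4 (0.94 log units; beyond the scatter), which makes compound 4 the most potent of the four compounds shown. The two larger steps are floors and not full sizes, since each starts from a limit of the assay: the limit of > 10000 nM in this assay, at which 2 of the 4 values shown sit.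

The step from compound 3 to compound 4 changes ring size and removes the methyl group together, so the compounds shown do not separate these two changes. An unsubstituted pyrrolidin-1-yl or piperidin-1-yl urea, or a methyl-substituted azepan-1-yl urea, would address this.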